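Aryl swap on the shorter chain: notes on compound 4

This account rests on a few compounds, and the source may have more. Where it says the series, first, only, none or still open, it means among the compounds named here.

Measured so far in an assay on membranes from liver for displacement of a labelled ligand from Sigma non-opioid intracellular receptor 1 (Rattus norvegicus), read by scintillation counting; a lower number here means a stronger inhibitor, a higher number a weaker inhibitor:
- compound 1 `Cc1ccc(CN(C)CCCCn2c(=O)oc3ccccc32)c(C)c1`: compound 1 gives 239 nM
- compound 2 `Cc1cccc(CN(C)CCCCn2c(=O)oc3ccccc32)c1`: compound 2 gives 102 nM
- compound 3 `Cc1cccc(CN(C)CCCn2c(=O)oc3ccccc32)c1`: compound 3 gives 1840 nM

Compound 2 and compound 1 share the longer chain and differ only in the aryl group: 2,4-dimethylphenyl in place of 3-methylphenyl on a saturated chain carbon bound to an amine nitrogen. That change gave a 2.3-fold higher number from compound 2 to compound 1 (0.37 log units; beyond the scatter), a modest loss.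

Compound 3 carries the shorter chain; how its core differs from that of compound 2 is not broken down here. Of the three numbers, compound 3 has the highest, and its gaps to compound 1 and compound 2 are both beyond the scatter, so among the measured compounds it is the weakest inhibitor.

Compound 4 `Cc1ccc(CN(C)CCCn2c(=O)oc3ccccc32)c(C)c1` is not yet measured. It stands to compound 3 as compound 1 stands to compound 2: 2,4-dimethylphenyl in place of 3-methylphenyl on a saturated chain carbon bound to an amine nitrogen. The place is the same in both cases, so the change is the same one, made on the shorter-chain core. Within the data shown here, with only one earlier instance of this change, the expectation rests on that step alone, applied to compound 3 and its value 1840 nM.

Compound 4 is therefore expected to move by a 2.2-fold higher number from compound 3 to compound 4 (0.34 log units; beyond the scatter), set beside the earlier 2.3-fold higher number from compound 2 to compound 1 (0.37 log units; beyond the scatter), with wide uncertainty since one prior example cannot show whether the step carries over between cores.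

The estimate for compound 4 in this assay is 4000 nM, with a likely range from 1500 nM to 12000 nM.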

Compound 4, inhibition constant: 1830 nM
The estimate for compound 4 lay 2.2-fold (0.34 log units) above the measured number; the measured number falls inside the stated range.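

In this assay, putting 2,4-dimethylphenyl in place of 3-methylphenyl on the core of compound 3 gives a 1.0-fold lower number from compound 3 to compound 4 (0.00 log units; within the scatter), so compound 3 and compound 4 cannot be told apart. Set beside the same change on the core of compound 2, this step does not separate from the earlier one: the same change on two cores in this assay, a 2.3-fold higher number (0.37 log units; beyond the scatter) from compound 2 to compound 1 and a 1.0-fold lower number (0.00 log units; within the scatter) from compound 3 to compound 4, 2.4-fold (0.37 log units) apart, within the scatter of two such steps. The two cores therefore give no sign that the change behaves differently from one to the other, but with a single pair on each core this does not show that the step is the same on both, and it gives no basis for a general rule on carrying the change to further cores in the series.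

The compounds shown leave open how the binding number responds to other groups at this place, such as an unsubstituted phenyl or a phenyl bearing a chlorine or methoxy group, since only two methyl-substituted aryl groups appear here. They also leave open whether the same comparison would hold on a longer chain, or with an ethyl group in place of the methyl group on the amine nitrogen.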